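Compound 2 to compound 3: one further hydroxy

The source may hold more compounds than are shown below. What is called first, only, known or untested is meant among the compounds shown, and "the series" means these compounds.

In a functional assay on A549 cells (Homo sapiens) for antiproliferative activity, read by MTT assay, with a stated time of 72 h (a higher number here means a weaker inhibitor, a lower number a stronger inhibitor), compound 1 (`O=c1oc2cc(O)ccc2cc1-c1ccc(O)cc1`) reaches only a limit, > 200000 nM. For the measured compounds named here, compound 2 (`O=c1oc2cc(O)ccc2cc1-c1ccc(O)c(O)c1`) gives 85000 nM, the only actual number so far. Compound 3 (`O=c1oc2cc(O)c(O)cc2cc1-c1ccc(O)c(O)c1`) shares the core of compound 2 and carries one change: hydroxy in place of hydrogen on an aromatic carbon. Going by the values given here, the single measured step that bears on this is an at least 2.3-fold lower number from compound 1 to compound 2 (0.37 log units; beyond the scatter), which is also hydroxy in place of hydrogen on an aromatic carbon, though at a different place. Its size is open-ended, given (the limit of > 200000 nM in this assay, at which 1 of the 2 values shown sits). One such step is thin support, but a further modest move to a lower number in this assay is expected. The expected change is a 2.1-fold lower number from compound 2 to compound 3 (0.33 log units; beyond the scatter). For compound 3 the estimated value is 40000 nM, with an expected range of 12000 nM to 120000 nM.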

Compound 3, half-maximal inhibitory concentration: 48800 nM
Compound 3: middle estimate off by 1.2-fold (0.09 log units), on the low side; low and high end bracket the measured number.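

In this assay, hydroxy in place of hydrogen on an aromatic carbon of the fused system, ortho to a hydroxy group, gives a 1.7-fold lower number from compound 2 to compound 3 (0.24 log units; within the scatter), so at this position the change cannot be told apart from the scatter of repeated measurements. The earlier hydroxy, at a different place, gave an at least 2.3-fold lower number from compound 1 to compound 2 (0.37 log units; beyond the scatter), so the same change does not give a step beyond the scatter at every place in these compounds. Compound 1 is only a limit, so the size of that earlier step stays open: the limit of > 200000 nM in this assay, at which 1 of the 3 values shown sits.

The compounds shown leave open whether a methoxy, an amine or a fluorine on this aromatic carbon would move the number beyond the scatter. Also open, from the compounds shown here alone, is whether the new hydroxy would behave the same without the hydroxy group it is ortho to.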